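Notes on compounds 1 to 4: a fluoro step repeated

A few compounds are considered here, and "the series" means these few. Any claim that something is new, unique, unknown or untested is made for them only; others in the source may bear on it.

Compound 1 `CC1(CO)OCC(n2ccc(N)nc2=O)O1` gives 30000 nM in a functional assay on CCRF-CEM cells (Homo sapiens) for inhibition; a lower number here means a stronger inhibitor, a higher number a weaker inhibitor.
Compound 2 `CC1(CO)OCC(n2cc(F)c(N)nc2=O)O1` gives only a limit of the assay, > 100000 nM.
Compound 3 `C[C@]1(CO)OCC(n2ccc(N)nc2=O)O1` likewise gives only a limit of the assay, > 100000 nM.

Compound 2 differs from compound 1 by fluoro in place of hydrogen on an aromatic carbon; this change brings an at least 3.3-fold higher number from compound 1 to compound 2 (0.52 log units; beyond the scatter). Compound 3 differs from compound 1 by the two compounds have the same atoms and bonds; at least one stereo element is drawn with a configuration in one of them and without one in the other: 1 of 2 stereo elements differ; a stereocentre at a saturated ring carbon is drawn without a configuration in compound 1 and S in compound 3; that is the whole of how the two cores differ, and the step is an at least 3.3-fold higher number from compound 1 to compound 3 (0.52 log units; beyond the scatter). Both steps are known only as lower bounds because of the limit of > 100000 nM in this assay, at which 2 of the 3 values shown sit. The step from compound 1 to compound 3 rests on nothing more than the fact that one of compounds 1 and 3 is drawn with a defined configuration and the other without, at the place where they differ.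

Compound 4 `C[C@]1(CO)OCC(n2cc(F)c(N)nc2=O)O1` has not been measured. It differs from compound 3 by fluoro in place of hydrogen on an aromatic carbon; the surroundings of the place read the same, word for word, as for the change from compound 1 to compound 2, so this is the same change, made here on the core of compound 3. In this assay compound 4 is expected to give 300000 nM, with a range of 100000 nM to 1500000 nM, and most likely the assay will again report only a limit. The expected step is a step that the limit leaves unreadable from compound 3 to compound 4. This expectation rests on compound 3 sitting at a limit, > 100000 nM. It also rests on compound 2 sitting at a limit, > 100000 nM, after the same change.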

Compound 4, half-maximal inhibitory concentration: > 100000 nM
Compound 4: no number, only a limit; the forecaster's own chance of this, stated with the estimate: 90%; the middle value does not contradict the limit.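

Neither step reaching compound 4 in this assay, from compound 3 or from compound 2, can be read, because each joins two limits of the assay: the limit of > 100000 nM in this assay, at which 3 of the 4 values shown sit. The compounds shown leave open how large the effect of fluoro in place of hydrogen is on the core of compound 3, and whether the drawn configuration matters at all in the fluoro pair.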